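Methyl to benzyl ester step in the series

A few compounds are considered here, and "the series" means these few. Any claim that something is new, unique, unknown or untested is made for them only; others in the source may bear on it.

Measured so far:
- compound 1 `C=C1CC[C@H]2[C@@](C)(CC[C@@H](OC(C)=O)[C@@]2(C)C(=O)OCc2ccccc2)[C@@H]1C/C=C1\C=COC1=O`: 78000 nM
- compound 2 `C=C1CC[C@H]2[C@@](C)(CC[C@@H](O)[C@@]2(C)C(=O)OC)[C@@H]1C/C=C1\C=COC1=O`: 177000 nM

Both values come from a functional assay on NIH3T3 cells (Mus musculus) for inhibition, read by MTT assay, with a stated time of 72 h; on this read-out higher numbers stand for weaker inhibition and lower numbers for stronger inhibition. Compound 2 stands highest of the two, so it is the weaker inhibitor, and its gap to compound 1 lies beyond the usual scatter. Compound 3 `C=C1CC[C@H]2[C@@](C)(CC[C@@H](O)[C@@]2(C)C(=O)OCc2ccccc2)[C@@H]1C/C=C1\C=COC1=O` is next. Its change from compound 2 is phenyl in place of hydrogen on a saturated chain carbon bound to an oxygen next to a carbonyl group, which also reads as methoxycarbonyl to benzyloxycarbonyl. Among the compounds with values here, no measured pair isolates this change, so the evidence in this assay is indirect. Compound 3 differs elsewhere from compound 1, which also carries benzyloxycarbonyl, and compound 1 gives 78000 nM. The expected 1.8-fold lower number from compound 2 to compound 3 (0.25 log units; within the scatter) is a modest one towards a lower number and may stay within the scatter. The estimated value for compound 3 is 100000 nM, with an expected range of 45000 nM to 200000 nM.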

Compound 3, half-maximal inhibitory concentration: 177000 nM
Compound 3: middle estimate off by 1.8-fold (0.25 log units), on the low side; the range from low to high includes it.
By their numbers in this assay, from the lowest: compound 1; then compounds 2 and 3 (each within the scatter of the next).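

In this assay the change from methoxycarbonyl to benzyloxycarbonyl now has a matched pair with the free hydroxyl held constant, and it reads no change at the digits printed from compound 2 to compound 3 (within the scatter), so the added phenyl leaves the read-out unmoved at this position. With benzyloxycarbonyl held constant, the change of hydrogen in place of acetyl on an oxygen on a saturated carbon reads a 2.3-fold higher number from compound 1 to compound 3 (0.36 log units; beyond the scatter), which makes the acetyl the one feature seen so far to separate these compounds beyond the scatter, with the acetylated compound 1 the stronger inhibitor. No measurement here speaks to the reason for either step.

The compounds shown leave open whether the ester change would read the same with the acetyl in place, as compound 1 has no methyl ester partner. They also leave open how a carboxylic acid or an amide at the ester position would read, or a longer acyl chain such as propionyl on the oxygen.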